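Replacing Carbamoyl with a Carbamate on a Biaryl Core

The source may hold more compounds than are shown below. What is called first, only, known or untested is meant among the compounds shown, and "the series" means these compounds.

Among the measured compounds shown here, compound 2 `NC(=O)c1ccc(-c2ccc(Cc3ccncc3)cc2)cc1` is the only member of this small set with a measured number in an assay for inhibition of steroid 17-alpha-hydroxylase/17,20 lyase (Homo sapiens); on this read-out lower numbers stand for stronger inhibition and higher numbers for weaker inhibition; in that assay compound 2 gives 1790 nM. Its companion compound 1 `CC(=O)Nc1ccc(-c2ccc(Cc3ccncc3)cc2)cc1` carries acetamido where compound 2 carries carbamoyl. In this assay compound 1 reaches only a limit of the assay, > 5000 nM. For the measured compounds named here, the single measured step, an at least 2.7-fold lower number from compound 1 to compound 2 (0.44 log units; beyond the scatter), rests on that limit (the limit of > 5000 nM in this assay, at which 1 of the 2 values shown sits), so only its lower bound is known.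

Compound 3 `CC(C)(C)OC(=O)Nc1ccc(-c2ccc(Cc3ccncc3)cc2)cc1` differs from compound 2 by (tert-butoxycarbonyl)amino in place of carbamoyl on an aromatic carbon. Going by the values given here, no measured step covers this exact change. Among the compounds with values here, the nearest comparison is compound 1, whose acetamido, like the (tert-butoxycarbonyl)amino of compound 3, places a carbonyl on the nitrogen attached to the ring, and the one measured step, an at least 2.7-fold lower number from compound 1 to compound 2 (0.44 log units; beyond the scatter), ran toward stronger inhibition for carbamoyl. Moving away from carbamoyl again is therefore expected to weaken inhibition, by an estimated 2.5-fold higher number from compound 2 to compound 3 (0.40 log units; beyond the scatter). Compound 3 is expected to give about 4500 nM in this assay, between 1500 nM and 15000 nM, with a real chance that only a limit is returned.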

Compound 3, half-maximal inhibitory concentration: 1370 nM
For compound 3 the middle estimate is 3.3-fold (0.52 log units) above the measured one, outside the stated range (below it).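

At this place, on an aromatic carbon para to a large group, (tert-butoxycarbonyl)amino with its 8 heavy atoms and carbamoyl with its 3 cannot be told apart in this assay: the step is a 1.3-fold lower number from compound 2 to compound 3 (0.12 log units; within the scatter). A carbonyl on the nitrogen attached to the ring therefore does not by itself put a compound at the limit of this read-out, since keeping that nitrogen and carbonyl and placing tert-butoxy in place of methyl on the carbonyl carbon gives an at least 3.6-fold lower number from compound 1 to compound 3 (0.56 log units; beyond the scatter). Compound 1 stands at a limit, so only the lower bound of that step is known: the limit of > 5000 nM in this assay, at which 1 of the 3 values shown sits.

The compounds shown leave open whether this gain belongs to tert-butoxy itself or would also appear with a smaller alkoxy group such as methoxy or ethoxy on the same carbonyl carbon. They also leave open how a free amine or a carboxylic acid in this place would compare with carbamoyl and (tert-butoxycarbonyl)amino, which here stand level within the scatter.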